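The compounds below may be only part of what the source reports. "The series", "measured", "known", "first", "only" and "open" are said of these compounds alone.

Of the compounds shown here, three sharing one core have been measured in an in vitro ADME assay on microsomes from liver (Homo sapiens) for metabolic stability; on this read-out lower numbers stand for a shorter-lived compound and higher numbers for a longer-lived compound. Compound 1 `Nc1nccc(-c2ccc3nc(C4COc5ccc(F)cc5C4)oc3c2)n1` gives 1.52 h in this assay. Compound 2 `Cc1[nH]ncc1-c1ccc2nc(C3COc4ccccc4C3)oc2c1` gives 1.17 h in this assay. Compound 3 `Nc1nccc(-c2ccc3nc(C4COc5ccc(F)cc5C4)[nH]c3c2)n1` gives 0.75 h in this assay, the lowest of the three numbers; its gap to compound 2 lies within the scatter, so the two cannot be told apart, while its gap to compound 1 lies beyond the scatter, so compound 1 is the longer-lived of that pair.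

Compound 4 `COc1ccc2c(c1)CC(c1nc3ccc(-c4ccnc(N)n4)cc3[nH]1)CO2` is the next compound and is not yet measured. It differs from compound 3 in one place: methoxy in place of fluoro on an aromatic carbon, set meta to a fused ring and para to a fused ring. For the measured compounds named here, no pair of measured compounds covers this change, so the data give no direction for it. The account therefore expects a step from compound 3 to compound 4 of about a 1.3-fold lower number from compound 3 to compound 4 (0.10 log units; within the scatter), which is taken as no step beyond the scatter, leaning slightly toward a shorter half-life. On that basis compound 4 is estimated to give 0.6 h in this assay, with a range from 0.3 h to 1.2 h.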

Compound 4, half-life: 0.467 h
Compound 4: middle estimate off by 1.3-fold (0.11 log units), on the high side; the measured number falls inside the stated range.
By their numbers in this assay, from the lowest: compounds 4, 3, 2 and 1 (each within the scatter of the next, the first and the last beyond it).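

At this position, on an aromatic carbon meta to a fused ring and para to a fused ring, methoxy in place of fluoro gives a 1.6-fold lower number from compound 3 to compound 4 (0.21 log units; within the scatter) in this assay. For the compounds shown here, this is the first comparison in the set between two compounds that differ in one place, and it shows that this exchange, on the core of compound 3, does not move the half-life by more than the scatter, so compound 3 and compound 4 cannot be told apart on this read-out. Nothing at hand gives a reason for this result, whether in measured properties of the two groups or in where on the compounds the breakdown takes place.

On these data alone, the reading rests on this one pair, so it remains open whether the same exchange would also stay within the scatter on the core of compound 1, or whether it holds only on the core of compound 3. As far as these compounds go, it is equally open how a hydroxyl group, a chlorine atom, a longer chain such as ethoxy, or an amine at this same position would fare in this assay.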